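This account rests on a few compounds, and the source may have more. Where it says the series, first, only, none or still open, it means among the compounds named here.

The measured compounds, each in a physicochemical assay for solubility, in phosphate buffer, with a stated time of 24 h, at pH 7.4, tested at 100 uM; on this read-out higher numbers stand for higher solubility and lower numbers for lower solubility:

compound 1 `O=C(NCc1ccc(S(=O)(=O)c2cccc(C(F)(F)F)c2)cc1)N1Cc2ccncc2C1` gives 10000 nM
compound 2 `CN1CCC(S(=O)(=O)c2ccc(CNC(=O)N3Cc4ccncc4C3)cc2)CC1` gives 240000 nM
compound 3 `O=C(NCc1ccc(S(=O)(=O)N2CCC[C@H](O)C2)cc1)N1Cc2ccncc2C1` gives 215000 nM

Compound 1 stands lowest of the three in this assay, and its distance to the other two is well beyond the scatter. Two steps start from it and both exchange the group on the sulfonyl sulfur: a 24-fold higher number from compound 1 to compound 2 (1.38 log units; beyond the scatter) and a 22-fold higher number from compound 1 to compound 3 (1.33 log units; beyond the scatter). Between the two products the difference is small, a 1.1-fold lower number from compound 2 to compound 3 (0.05 log units; within the scatter), so the 1-methylpiperidin-4-yl and 3-hydroxypiperidin-1-yl groups land in the same place.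

Compound 4 `CN1CCN(S(=O)(=O)c2ccc(CNC(=O)N3Cc4ccncc4C3)cc2)CC1` is not yet measured. It differs from compound 1 in the same position: 4-methylpiperazin-1-yl in place of 3-(trifluoromethyl)phenyl on a sulfonyl sulfur. The two measured steps from compound 1 are the relevant precedents, and both are large and upward. Compound 4 is therefore expected to move upward by a comparable amount, an estimated 22-fold higher number from compound 1 to compound 4 (1.34 log units; beyond the scatter). The value of compound 4 in this assay is estimated at 220000 nM, with a range from 100000 nM to 400000 nM.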

Compound 4, solubility: 160000 nM
Estimate against measurement, compound 4: 1.4-fold (0.14 log units) above, and the stated range covers the measured number.
By their numbers in this assay, from the lowest: compound 1; then compounds 4, 3 and 2 (each within the scatter of the next).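

In this assay, among the compounds shown here, 4-methylpiperazin-1-yl on the sulfonyl sulfur gives a third large step away from 3-(trifluoromethyl)phenyl (a 16-fold higher number from compound 1 to compound 4 (1.20 log units; beyond the scatter)), so the rise now holds for three different non-aromatic rings, and compound 1 remains the only compound apart from the others. Compound 4 cannot be separated from its two neighbours, since both a 1.3-fold lower number from compound 3 to compound 4 (0.13 log units; within the scatter) and a 1.5-fold lower number from compound 2 to compound 4 (0.18 log units; within the scatter) lie within the scatter, and exchanges among these three groups have so far shown no measurable effect here. No measured evidence accounts for these steps.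

All three entering groups contain a ring nitrogen, so the compounds shown cannot separate the departure of the aryl group from the arrival of that nitrogen. A plain cyclohexyl or an unsubstituted phenyl on the same sulfur would address that question.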